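The compounds below may be only part of what the source reports. "The series", "measured", "known", "first", "only" and "open" are said of these compounds alone.

Of the compounds shown here, three sharing one core have been read in an ADME assay on microsomes from liver (Homo sapiens) for metabolic stability, read by LC-MS, with NADPH named in the record, with a stated time of 60 min, tested at 1 uM, in the absence of a further agent; on this read-out higher numbers stand for a more stable compound and lower numbers for a less stable compound: compound 1 `COc1ccc(-c2c(C)nc3c(N4CC[C@@H](NC(C)=O)C4)cc(C)nn23)cc1OC`, compound 2 `COc1ccc(-c2c(C)nc3c(N4CC[C@@H](NC(=O)OCc5ccccc5)C4)cc(C)nn23)cc1OC` and compound 3 `COc1ccc(-c2c(C)nc3c(N4CC[C@@H](NS(=O)(=O)C(C)C)C4)cc(C)nn23)cc1OC`. Compound 1 gives > 95%, which is a limit of the assay and not a number. Compound 2 gives > 95%, which is also a limit. Compound 3 gives > 95%, again a limit. All three therefore stand at the same point, (the limit of > 95% in this assay, at which 3 of the 3 values shown sit), and compound 3 has no exact value.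

Compound 4 `COc1ccc(-c2c(C)nc3c(N4CC[C@@H](NS(=O)(=O)c5ccccc5)C4)cc(C)nn23)cc1OC` differs from compound 3 in one place: phenyl in place of isopropyl on a sulfonyl sulfur, (phenyl in place of isopropyl on a sulfonyl sulfur).

The measured steps bearing on this change are a step that the two limits leave unreadable from compound 1 to compound 3, a step that the two limits leave unreadable from compound 2 to compound 3 and a step that the two limits leave unreadable from compound 1 to compound 2. None of them has a readable size, so they give no direction for the new step. What they do show is that replacing the group on the amine nitrogen has not yet moved any of these compounds off the limit, and compound 2 keeps that limit while carrying benzyloxycarbonyl there. No step beyond the scatter is therefore expected in this assay. The expected size is a number no higher from compound 3 to compound 4 (the limit leaves the size open), an estimate that stays within the usual scatter. For compound 4 the estimated value is 95%, with an expected range from 80% to 100%.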

Compound 4, percent of the compound remaining: > 95%
Compound 4: only a limit was reported; the forecaster's own chance of this, stated with the estimate: 65%; the middle value lies on the limit itself.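

In this assay compound 4 gives > 95%, which is a limit of the assay and not a number, so its steps from compound 1, compound 2 and compound 3 cannot be read. All four compounds stand at one point: the limit of > 95% in this assay, at which 4 of the 4 values shown sit.

The compounds shown leave open whether any change of the group on the amine nitrogen would bring a compound off this limit in this assay.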